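Moving a methyl group on the amide of compound 2

This account rests on a few compounds, and the source may have more. Where it says the series, first, only, none or still open, it means among the compounds named here.

In a physicochemical assay for solubility, read by spectrophotometry, measured as kinetic solubility, at pH 8, tested at 500 uM (a lower number here means a less soluble compound, a higher number a more soluble compound), compound 1 `CC(=O)N1CCCC(NC(=O)c2ccncc2Nc2cc(-c3ccc4ccn(C)c4c3)c3nccnc3c2)C1` gives 212 ug/mL, and compound 2 `CN1CCC(CNC(=O)c2ccncc2Nc2cc(-c3ccc4ccn(C)c4c3)c3nccnc3c2)C1` gives 246 ug/mL. These two numbers lie within the scatter of each other, so compound 2 cannot be separated from compound 1. Compound 3 `CN1CCC(N(C)C(=O)c2ccncc2Nc2cc(-c3ccc4ccn(C)c4c3)c3nccnc3c2)C1` has the same atoms as compound 2, joined differently: methyl(1-methylpyrrolidin-3-yl)amino in place of ((1-methylpyrrolidin-3-yl)methyl)amino on a carbonyl carbon. In short, methyl(1-methylpyrrolidin-3-yl)amino takes the place of ((1-methylpyrrolidin-3-yl)methyl)amino on a carbonyl carbon. Within the data shown here, only one measured step bears on this change, as it also swaps the group on the amide-type nitrogen: a 1.2-fold higher number from compound 1 to compound 2 (0.06 log units; within the scatter). Among the measured compounds shown here, that step stayed within the scatter, but no measured pair tests this exact rearrangement, so the evidence is thin. The expected change is a 1.1-fold lower number from compound 2 to compound 3 (0.03 log units; within the scatter), which means no shift beyond the scatter in either direction. For compound 3 the estimated value is 230 ug/mL, with an expected range of 140 ug/mL to 270 ug/mL.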

Compound 3, solubility: 245 ug/mL
Beside the measured number, compound 3's estimate is 1.1-fold (0.03 log units) below it; low and high end bracket the measured number.
By their numbers in this assay, from the lowest: compounds 1, 3 and 2 (each within the scatter of the next).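

In this assay, the swap of ((1-methylpyrrolidin-3-yl)methyl)amino for methyl(1-methylpyrrolidin-3-yl)amino on a carbonyl carbon gives a 1.0-fold lower number from compound 2 to compound 3 (0.00 log units; within the scatter) and stays within the scatter, so this rearrangement of the same atoms, which takes the hydrogen-bond donor count of the group from 1 to 0, cannot be told apart from no change at all. The step with a different group entering gives the same reading, a 1.2-fold higher number from compound 1 to compound 3 (0.06 log units; within the scatter) and so, on this carbonyl carbon, the three groups shown cannot be separated from one another. No measurement here offers a reason for this absence of a shift.

On these data alone, what remains open is whether a more different group on this carbonyl carbon, such as a longer chain ending in a primary amine or one ending in a carboxylic acid, would move the number beyond the scatter.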